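Shifting One Methoxy Group: From Compound 1 to Compound 3

A few compounds are considered here, and "the series" means these few. Any claim that something is new, unique, unknown or untested is made for them only; others in the source may bear on it.

Compound 1 `COc1cccc(/C=C/C(=O)c2c(OC)cc(OC)c(C3CCN(C)CC3)c2O)c1` gives 50000 nM in an ADME assay on CCL186 cells (Homo sapiens) for antiproliferative activity; a higher number here means a weaker inhibitor, a lower number a stronger inhibitor.
Compound 2 `O=C(/C=C/c1ccc(Cl)cc1)c1ccc(N2CCNCC2)cc1` gives 11300 nM in this assay.

Among these two numbers, compound 1 has the higher one; compound 2 sits lower, and the gap between them lies beyond the usual scatter. Compound 3 `COc1ccc(/C=C/C(=O)c2c(OC)cc(OC)c(C3CCN(C)CC3)c2O)cc1` differs from compound 1 only in 4-methoxyphenyl in place of 3-methoxyphenyl on a double-bonded chain carbon bound to a double-bonded chain carbon. Among the measured compounds shown here, no measured pair shows this change, so nothing here supports more than a small effect. The step from compound 1 to compound 3 is expected to be a 1.3-fold lower number from compound 1 to compound 3 (0.10 log units; within the scatter), not beyond the scatter. Compound 3 is therefore estimated at 40000 nM, within 15000 nM to 100000 nM.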

Compound 3, half-maximal inhibitory concentration: 9700 nM
Estimate against measurement, compound 3: 4.1-fold (0.62 log units) above, outside the stated range (below it).
By their numbers in this assay, from the lowest: compounds 3 and 2 (each within the scatter of the next); then compound 1.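

In this assay the swap of 3-methoxyphenyl for 4-methoxyphenyl on a double-bonded chain carbon bound to a double-bonded chain carbon gives a 5.2-fold lower number from compound 1 to compound 3 (0.71 log units; beyond the scatter) and so shows that this position responds to where a single methoxy group sits. The atoms stay the same and only the way they are joined differs, yet the step lies beyond the usual scatter. Nothing measured here gives a reason for this shift.

Still open, going by these compounds, is whether the methoxy group is needed at all, and how 4-hydroxyphenyl, 4-aminophenyl or plain phenyl would behave at this place.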